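Swapping an ester for an alcohol on the amide side chain

The compounds below may be only part of what the source reports. "The series", "measured", "known", "first", "only" and "open" are said of these compounds alone.

Compound 1 `CCn1c(C(=O)N[C@H](C)C(=O)OC)ccc1C(CC)(CC)c1ccc(OCS(=O)(=O)c2ccccc2)c(C)c1` is tested in a functional assay on MCF7 cells (Homo sapiens) for antiproliferative activity, read by MTT assay, with a stated time of 24 h; on this read-out higher numbers stand for weaker inhibition and lower numbers for stronger inhibition. In this assay compound 1 gives only a limit, > 50000 nM, not a number. Compound 2 `CCn1c(C(=O)N[C@@H](CC(=O)OC)C(=O)OC)ccc1C(CC)(CC)c1ccc(OCS(=O)(=O)c2ccccc2)c(C)c1` likewise gives only a limit, > 50000 nM. Compound 3 `CCn1c(C(=O)NCCN)ccc1C(CC)(CC)c1ccc(OCS(=O)(=O)c2ccccc2)c(C)c1` gives 6470 nM, so the shift an at least 7.7-fold lower number from compound 1 to compound 3 (0.88 log units; beyond the scatter) and the shift an at least 7.7-fold lower number from compound 2 to compound 3 (0.88 log units; beyond the scatter) both reach a measurable number once a 2-aminoethyl group sits on the amide-type nitrogen. Compound 4 `CCn1c(C(=O)N[C@H](C)CO)ccc1C(CC)(CC)c1ccc(OCS(=O)(=O)c2ccccc2)c(C)c1` differs from compound 1 by hydroxymethyl in place of methoxycarbonyl on a saturated chain carbon bound to an amide-type nitrogen and a saturated chain carbon. Among the measured compounds shown here, no measured pair tests this exact change, but compound 3 shows that a small polar chain can bring the number within range, while compound 1 and compound 2 sit at the limit of > 50000 nM in this assay, at which 2 of the 3 values shown sit. A small lowering is therefore expected, an at least 1.6-fold lower number from compound 1 to compound 4 (0.22 log units; that floor lies within the scatter), and compound 4 is estimated at 30000 nM, ranging from 8000 nM to 120000 nM.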

Compound 4, half-maximal inhibitory concentration: 10600 nM
Compound 4: middle estimate off by 2.8-fold (0.45 log units), on the high side; low and high end bracket the measured number.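

Putting hydroxymethyl in place of methoxycarbonyl on this saturated chain carbon brings a measurable number in this assay, with an at least 4.7-fold lower number from compound 1 to compound 4 (0.67 log units; beyond the scatter), and the comparison with the other ester gives an at least 4.7-fold lower number from compound 2 to compound 4 (0.67 log units; beyond the scatter). Both steps are floors, not exact sizes, since compound 1 and compound 2 give only a limit: the limit of > 50000 nM in this assay, at which 2 of the 4 values shown sit. The remaining step, a 1.6-fold higher number from compound 3 to compound 4 (0.21 log units; within the scatter), shows that the 1-(hydroxymethyl)ethyl and 2-aminoethyl chains cannot be told apart here, so a measurable number does not depend on an amine.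

Still open, going by these compounds, is whether a carboxylic acid at this carbon, or a longer chain ending in an alcohol, would give a lower number.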